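Notes on a ring-nitrogen substituent swap across two cores

The compounds below may be only part of what the source reports. "The series", "measured", "known", "first", "only" and "open" are said of these compounds alone.

Compound 1 `CC(C)n1cnc2c(Nc3ccccc3)nc(NCOCc3ccc(C(=O)Nc4ccccc4N)cc3)nc21` is tested in a functional assay on HepG2 cells (Homo sapiens) for antiproliferative activity, read by CCK-8 assay, with a stated time of 72 h, tested at 8 uM (a lower number here means a weaker effect, a higher number a stronger effect of the compound at the concentration tested), where compound 1 gives 50.2%. Compound 3 `CC(C)n1cnc2c(Nc3cccc(Cl)c3)nc(NCOCc3ccc(/C=C/C(=O)Nc4ccccc4N)cc3)nc21` gives 49.9% in this assay; these two numbers lie within the usual scatter of each other, so no order between compound 1 and compound 3 is read from them. How the core of compound 1 and the core of compound 3 differ is not broken down here. Compound 2 `Nc1ccccc1NC(=O)/C=C/c1ccc(COCNc2nc(Nc3cccc(Cl)c3)c3ncn(C4CCCC4)c3n2)cc1` gives 14.8% in this assay. The step of a number 35.1 percentage points lower from compound 3 to compound 2 (beyond the scatter) goes with the structural change (cyclopentyl in place of isopropyl on an aromatic nitrogen), which among the compounds here occurs twice in all.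

The second occurrence, (cyclopentyl in place of isopropyl on an aromatic nitrogen), leads from compound 1 to compound 4 `Nc1ccccc1NC(=O)c1ccc(COCNc2nc(Nc3ccccc3)c3ncn(C4CCCC4)c3n2)cc1`, which has not yet been measured in this assay. The place of the change reads the same word for word in both pairs, so it is the same change, not merely the same kind. Going by the values given here, only one measured instance of it exists, on a single pair of compounds, so the size carried over to the new pair is uncertain and is taken from that one pair alone.

For compound 4 the expected step is a number 34.2 percentage points lower from compound 1 to compound 4 (beyond the scatter) in this assay, because the same change gave a number 35.1 percentage points lower from compound 3 to compound 2 (beyond the scatter). The estimate for compound 4 in this assay is 16%, expected to fall between 4% and 32%.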

Compound 4, a percentage reported as inhibition, at one concentration (the size of the read-out at that concentration, not a potency): 66.9%
Compound 4: middle estimate off by 50.9 percentage points, on the low side, and the stated range ends below it.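

In this assay, cyclopentyl in place of isopropyl on an aromatic nitrogen goes with a number 16.7 percentage points higher from compound 1 to compound 4 (beyond the scatter), so on the core of compound 1 the swap does not behave as it did on the core of compound 3. Set side by side, the two steps point in opposite directions and do not agree in size: the same change on two cores in this assay, a number 35.1 percentage points lower (beyond the scatter) from compound 3 to compound 2 and a number 16.7 percentage points higher (beyond the scatter) from compound 1 to compound 4, 51.8 percentage points apart, beyond the scatter of two such steps This shows that, in this series, a step measured for this swap on one core cannot be carried over to the other core, but it rests on one pair per core and a read-out at a single concentration, and it does not show which difference between the cores goes with the reversal or why the reversal occurs.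

The compounds shown leave open whether the reversal follows the chlorine, the double bond, or both, as compound 2 and compound 3 carry these features while compound 1 and compound 4 do not. They also leave open how the response on each core changes with other groups on the same ring nitrogen, such as a cyclohexyl or an ethyl group, and so whether isopropyl and cyclopentyl mark part of a wider trend on either core.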